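The source may hold more compounds than are shown below. What is called first, only, known or untested is meant among the compounds shown, and "the series" means these compounds.

Measured in an ADME assay on MDBK cells (Bos taurus) for cytotoxicity, read by MTT assay, with a stated time of 96 h; a lower number here means that less compound is tolerated, a higher number that more compound is tolerated:
Compound 1 `FC(F)(F)c1cccc(NC(=S)Nc2ccc(I)cc2)c1`: 9500 nM
Compound 2 `FC(F)(F)c1cccc(NC(=S)Nc2ccccc2)c1`: 49000 nM
Compound 3 `CSCCCNC(=S)Nc1cccc(C(F)(F)F)c1`: > 100000 nM (a limit)

Compound 3 stands at the limit of > 100000 nM in this assay, at which 1 of the 3 values shown sits, so it gives a limit and not a number. Compound 4 `Fc1ccccc1NC(=S)Nc1cccc(C(F)(F)F)c1` differs from it by 2-fluorophenyl in place of 3-(methylsulfanyl)propyl on an amide-type nitrogen.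

For the measured compounds named here, two measured steps bear on this change, both running the opposite way, from an aromatic group to the same chain. The closer one is an at least 2.0-fold higher number from compound 2 to compound 3 (0.30 log units; that floor lies within the scatter), and the other, which carries the iodo group compound 4 lacks, is an at least 10-fold higher number from compound 1 to compound 3 (1.02 log units; beyond the scatter). That iodo group also counts in a 5.2-fold higher number from compound 1 to compound 2 (0.71 log units; beyond the scatter), so compound 1 is the weaker guide. A modest step to a lower number is therefore expected in this assay, although the limit on compound 3 hides its true size. The expected change is an at least 2.5-fold lower number from compound 3 to compound 4 (0.39 log units; beyond the scatter). Compound 4 is estimated at 40000 nM, with an expected range from 12000 nM to 100000 nM.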

Compound 4, half-maximal cytotoxic concentration: > 100000 nM
Compound 4 ended at the assay's limit; the forecaster's own chance of this, stated with the estimate: 20%; at least 2.5-fold (0.39 log units) between middle value and limit.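

In this assay compound 4, which carries an aromatic 2-fluorophenyl group on the amide-type nitrogen, gives > 100000 nM, a limit and not a number, so reaching the limit is not confined to the 3-(methylsulfanyl)propyl chain. Fluoro in place of hydrogen gives an at least 2.0-fold higher number from compound 2 to compound 4 (0.30 log units; that floor lies within the scatter), so this change is not shown to go beyond the scatter, whereas 2-fluorophenyl in place of 4-iodophenyl gives an at least 10-fold higher number from compound 1 to compound 4 (1.02 log units; beyond the scatter). The step between the chain and 2-fluorophenyl cannot be read, since both compounds stand at the same limit: the limit of > 100000 nM in this assay, at which 2 of the 4 values shown sit.

Going by these compounds, how far beyond the limit compound 3 and compound 4 lie remains open. Also open, on these data alone, is how chloro or methoxy in place of the fluoro, or an amine on the same ring, would read in this assay.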